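This account rests on a few compounds, and the source may have more. Where it says the series, first, only, none or still open, it means among the compounds named here.

In a toxicity assay on THP-1 cells (Homo sapiens) for inhibition (on this read-out higher numbers stand for lower toxicity in this test and lower numbers for higher toxicity in this test), three compounds on a shared core have been measured: compound 1 (`COc1ccc(-c2cnc(NC(=O)c3ccccc3O)n2C)cc1`), compound 2 (`COc1ccc(-c2cnc(NC(=O)C3CCNCC3)n2C)cc1`) and compound 3 (`COc1ccc(-c2cnc(NC(=O)c3cccc([N+](=O)[O-])c3)n2C)cc1`). Compound 1 gives > 100000 nM, which is a limit of the assay and not a number. Compound 2 gives > 100000 nM, which is also a limit. Compound 3 gives > 100000 nM, again a limit. Compound 2 therefore has no number of its own and stands level with the other two only in this sense: the record so far is the limit of > 100000 nM in this assay, at which 3 of the 3 values shown sit.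

Compound 4 (`COc1ccc(-c2cnc(NC(=O)c3ccc(Br)cc3)n2C)cc1`) has not yet been measured. Its difference from compound 2 is 4-bromophenyl in place of piperidin-4-yl on a carbonyl carbon, so a six-membered aromatic ring of carbon only now stands on the carbonyl carbon.

Within the data shown here, the one measured step that bears on this change is a step that the two limits leave unreadable from compound 1 to compound 2, with piperidin-4-yl in place of 2-hydroxyphenyl on a carbonyl carbon. That step gives no size to carry over, and the limit shared by all three compounds offers no measured shift in either direction. Little change is therefore expected in this assay, with any readable movement expected toward lower numbers. The expected change is an at least 1.1-fold lower number from compound 2 to compound 4 (0.04 log units; that floor lies within the scatter). For compound 4 the estimate is 90000 nM, with an expected range from 35000 nM to 100000 nM.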

Compound 4, half-maximal cytotoxic concentration: > 100000 nM
Compound 4: only a limit was reported; the forecaster's own chance of this, stated with the estimate: 70%; at least 1.1-fold (0.04 log units) between middle value and limit.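

Compound 4 also sits at a limit of the assay and not at a number, so neither the step from compound 1 to compound 4 nor the step from compound 2 to compound 4 can be read. The compounds shown leave open whether any group on the carbonyl carbon changes the number in this assay, and the record stands as follows: the limit of > 100000 nM in this assay, at which 4 of the 4 values shown sit.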